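Fluorine added to an aryl ether series without readable toxicity

A few compounds are considered here, and "the series" means these few. Any claim that something is new, unique, unknown or untested is made for them only; others in the source may bear on it.

Compound 1, with the structure `Cc1nc(C)c([C@H](OC(C)(C)C)C(=O)O)c(N2CCC(C)(C)CC2)c1-c1ccc(Cc2ccccc2)cc1`, was tested in a toxicity assay on MT2 cells (Homo sapiens) for cytotoxicity, read by XTT assay, with a stated time of 4 days; on this read-out lower numbers stand for higher toxicity in this test and higher numbers for lower toxicity in this test. In that assay compound 1 gives >= 20000 nM, which is a limit of the assay rather than a measured number. Compound 2, with the structure `Cc1ccc(CCOc2ccc(-c3c(C)nc(C)c([C@H](OC(C)(C)C)C(=O)O)c3N3CCC(C)(C)CC3)cc2)cc1`, differs from it by 2-(4-methylphenyl)ethoxy in place of benzyl on an aromatic carbon. In this assay compound 2 gives >= 33500 nM, again only a limit. The step that the two limits leave unreadable from compound 1 to compound 2 therefore cannot be sized. Compound 2 thus stands at the limit of >= 33500 nM in this assay, at which 1 of the 2 values shown sits. Compound 1 stands at the limit of >= 20000 nM in this assay, at which 1 of the 2 values shown sits. Neither point supplies a number.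

Compound 3, with the structure `Cc1cc(CCOc2ccc(-c3c(C)nc(C)c([C@H](OC(C)(C)C)C(=O)O)c3N3CCC(C)(C)CC3)cc2)ccc1F`, carries 4-fluoro-3-methylphenyl in place of 4-methylphenyl on a saturated chain carbon, two bonds along the chain from an oxygen on an aromatic ring. Among the compounds with values here, the single measured step is unreadable, so it offers no size to carry forward; the structural change itself is a small one on the outer ring of the chain. The step of an at least 1.1-fold lower number from compound 2 to compound 3 (0.04 log units; that floor lies within the scatter) is therefore expected to be none beyond the scatter, with compound 3 most likely returning another limit. Compound 3 is estimated at 30000 nM, within a range from 15000 nM to 60000 nM.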

Compound 3, half-maximal cytotoxic concentration: >= 33500 nM
Compound 3: a limit, no number; the forecaster's own chance of this, stated with the estimate: 85%; at least 1.1-fold (0.04 log units) between middle value and limit.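

In this assay compound 3 gives >= 33500 nM, which is a limit and not a number. Within the data shown here, compound 1, compound 2 and compound 3 all stand as limits, so no step among them can be read. As far as these compounds go, it remains open how toxic these compounds are, and whether 4-fluoro-3-methylphenyl in place of 4-methylphenyl changes that at all.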